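Hydroxy to amino on the shared core: compound 3 to compound 4

A few compounds are considered here, and "the series" means these few. Any claim that something is new, unique, unknown or untested is made for them only; others in the source may bear on it.

Measured so far in a functional assay on B16 cells (Mus musculus) for inhibition, tested at 3 ug/mL; on this read-out lower numbers stand for less inhibition and higher numbers for more inhibition at the one concentration tested (going by the name of the read-out):
compound 1 `COc1cc2oc(=O)cc(COC(=O)/C=C/c3cc(OC)c(OC)c(OC)c3)c2cc1OC` gives 18.7%.
compound 2 `COc1cc2oc(=O)cc(COC(=O)/C=C/c3ccc(Cl)cc3)c2cc1OC` gives only a limit, < 10%.
compound 3 `COc1cc2oc(=O)cc(COC(=O)/C=C/c3ccc(O)cc3)c2cc1OC` gives 19.7%.

Compound 3 stands alongside compound 1; the two numbers lie within the scatter of each other, and the remaining value is a limit. Among the compounds with values here, the one measured step leading to compound 3 is a number at least 9.7 percentage points higher from compound 2 to compound 3 (that floor lies within the scatter), which amounts to hydroxy in place of chloro on an aromatic carbon; its floor lies within the scatter, and its size is bounded only by the limit of < 10% in this assay, at which 1 of the 3 values shown sits.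

Compound 4 `COc1cc2oc(=O)cc(COC(=O)/C=C/c3ccc(N)cc3)c2cc1OC` is yet to be measured in this assay. The change is amino in place of hydroxy on an aromatic carbon. No measured step swaps hydroxy for amino, so no shown step bears directly on it; the change keeps the counted donor and acceptor, and nothing among the shown compounds argues for movement beyond the scatter in either direction. Compound 4 is expected to give about 17%, in the range 8% to 30%. That estimate means an expected step of a number 2.7 percentage points lower from compound 3 to compound 4 (within the scatter), within the scatter.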

Compound 4, a percentage reported as inhibition, at one concentration (the size of the read-out at that concentration, not a potency): < 10%
Compound 4: a limit, no number; the forecaster's own chance of this, stated with the estimate: 20%; middle value at least 7 percentage points away from the limit.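

In this assay, amino in place of hydroxy on this aromatic carbon, para to a large group, gives a number at least 9.7 percentage points lower from compound 3 to compound 4 (that floor lies within the scatter), so keeping the counted donor and acceptor does not by itself keep a readable number at this position, though the floor of that step stays within the scatter. The value of compound 4 is a limit, not a number, and it places amino with chloro rather than hydroxy on this read-out. The step between the amino and chloro compounds cannot be read, and the two groups cannot be ordered: the limit of < 10% in this assay, at which 2 of the 4 values shown sit.

On these data alone, how far amino and chloro actually fall under that limit stays open. Also open, as far as these compounds go, is whether a carboxylic acid or an acetamido group at this position would give a readable number, as hydroxy does.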